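This account rests on a few compounds, and the source may have more. Where it says the series, first, only, none or still open, it means among the compounds named here.

In a functional assay on A549 cells (Homo sapiens) for antiproliferative activity, read by MTT assay, with a stated time of 72 h (on this read-out higher numbers stand for weaker inhibition and lower numbers for stronger inhibition), compound 1 `COc1cc(CCc2ccccc2)cc(OC)c1O` gives 10900 nM while compound 2 `COc1cc(CCc2ccccc2Cl)cc(OC)c1O` gives 2130 nM and compound 3 `COc1cc(CCc2cccc(Cl)c2Cl)cc(OC)c1O` gives 3990 nM on the same read-out. Compound 2 thus stands clear of compound 1 but level with compound 3 within the scatter. Going by the values given here, compound 4 `COc1cc(CCc2ccc(Cl)cc2Cl)cc(OC)c1O` carries chloro in place of hydrogen on an aromatic carbon as its one difference from compound 2: chloro in place of hydrogen on an aromatic carbon. The same kind of change first brought a 5.1-fold lower number from compound 1 to compound 2 (0.71 log units; beyond the scatter) as a modest step. The closer precedent adds a second chloro and brought a 1.9-fold higher number from compound 2 to compound 3 (0.27 log units; within the scatter) so no step beyond the scatter is expected in this assay here. The estimated step is a 1.4-fold higher number from compound 2 to compound 4 (0.15 log units; within the scatter) in size. For compound 4 the estimate is 3000 nM with 1000 nM to 9000 nM as the expected range.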

Compound 4, half-maximal inhibitory concentration: 3840 nM
Beside the measured number, compound 4's estimate is 1.3-fold (0.11 log units) below it; measured number inside the range.
By their numbers in this assay, from the lowest: compounds 2, 4 and 3 (each within the scatter of the next); then compound 1.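

In this assay, chloro entering para to a large group and meta to a chloro group gives a 1.8-fold higher number from compound 2 to compound 4 (0.26 log units; within the scatter). Unlike the first chloro in a 5.1-fold lower number from compound 1 to compound 2 (0.71 log units; beyond the scatter), this second chloro leaves the number within the scatter, so this position shows no gain or loss over compound 2 on this read-out. Nothing shown accounts for this result. Going by these compounds, it remains open whether an amine or a carboxylic acid at this same position would move the number beyond the scatter. The compounds shown also leave open what a fluoro or a methoxy group would do there.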